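Pentyl to phenethyl on the triazole-bearing core of compound 1

The compounds below may be only part of what the source reports. "The series", "measured", "known", "first", "only" and "open" are said of these compounds alone.

Measured so far:
compound 1 `CCCCCCOc1ccc(-n2cnnc2CCCCC)cc1` gives 32.8 mg/kg in a functional assay on the whole organism (strain C57B/6) with Mus musculus as the target, in the maximal electroshock model; on this read-out lower numbers stand for an effect already at smaller amounts and higher numbers for an effect only at larger amounts of compound.
compound 2 `CCCCCCCCCc1nncn1-c1ccc(OCCCCCC)cc1` reaches only a limit of the assay, > 40 mg/kg.
compound 3 `CCCCCCOc1ccc(-n2cnnc2-c2cccc(F)c2)cc1` gives 27.4 mg/kg.

Compound 1 holds the highest of the two numbers obtained; compound 3 is nearest, with a 1.2-fold lower number from compound 1 to compound 3 (0.08 log units; within the scatter), a gap that lies within the scatter. The value of compound 2 is a limit of the assay and not a number, namely (the limit of > 40 mg/kg in this assay, at which 1 of the 3 values shown sits).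

Compound 4 `CCCCCCOc1ccc(-n2cnnc2CCc2ccccc2)cc1` has not yet been measured. It differs from compound 1 as follows: phenyl in place of propyl on a saturated chain carbon, two bonds along the chain from an aromatic carbon. Going by the values given here, two measured steps bear on this change. Exchanging pentyl for an aromatic ring gave a 1.2-fold lower number from compound 1 to compound 3 (0.08 log units; within the scatter), within the scatter. Extending the chain by butyl gave an at least 1.2-fold higher number from compound 1 to compound 2 (0.08 log units; that floor lies within the scatter), which only sets a floor. Compound 4 keeps a chain close in length to pentyl and ends in a ring, so no step beyond the scatter is expected in this assay. The expected step is a 1.1-fold lower number from compound 1 to compound 4 (0.04 log units; within the scatter). Compound 4 is therefore estimated at 30 mg/kg, with a range from 15 mg/kg to 60 mg/kg.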

Compound 4, dose for half-maximal effect: 27.4 mg/kg
Estimate against measurement, compound 4: 1.1-fold (0.04 log units) above, and the stated range covers the measured number.
By their numbers in this assay, from the lowest: compounds 3, 4 and 1 (each within the scatter of the next). At a limit, above all of these: compound 2.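

In this assay, phenyl in place of propyl on a saturated chain carbon, two bonds along the chain from an aromatic carbon, gives a 1.2-fold lower number from compound 1 to compound 4 (0.08 log units; within the scatter), so a chain that ends in a ring sits at this position without a step beyond the scatter. Phenethyl in place of 3-fluorophenyl on an aromatic carbon gives no change at the digits printed from compound 3 to compound 4 (within the scatter), so in this read-out a ring carried out on a chain and a ring standing directly on the aromatic carbon cannot be told apart. The step against the nonyl chain, an at least 1.4-fold lower number from compound 2 to compound 4 (0.16 log units; that floor lies within the scatter), starts from a limit of the assay and is a floor only: the limit of > 40 mg/kg in this assay, at which 1 of the 4 values shown sits.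

Compounds 1, 3 and 4 all lie within the scatter of one another, so they give no order among pentyl, 3-fluorophenyl and phenethyl at this position. From the compounds shown here alone, whether an amine or a carboxylic acid on the phenethyl ring, or a longer chain between that ring and the core, would move the number beyond the scatter stays open.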